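Ether variation at the ketone-adjacent carbon in the shared core

The compounds below may be only part of what the source reports. "The series", "measured", "known", "first", "only" and "open" are said of these compounds alone.

Compound 1 `CC(C)[C@H](NC(=O)COc1cccc2ccccc12)C(=O)N[C@@H](CC(=O)O)C(=O)CSc1nc(-c2ccccc2)no1` gives 102000 nM in a functional assay on Jurkat cells (Homo sapiens) for inhibition; a higher number here means a weaker inhibitor, a lower number a stronger inhibitor. Compound 2 `CC(C)[C@H](NC(=O)COc1cccc2ccccc12)C(=O)N[C@@H](CC(=O)O)C(=O)COc1cc(C(F)(F)F)ncn1` returns only a limit of this assay, > 200000 nM. Compound 3 `CC(C)[C@H](NC(=O)COc1cccc2ccccc12)C(=O)N[C@@H](CC(=O)O)C(=O)COc1nccc(C(F)(F)F)n1` likewise returns only a limit of this assay, > 200000 nM.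

Compound 3 thus stands at the limit of > 200000 nM in this assay, at which 2 of the 3 values shown sit, with no number of its own. Among the measured compounds shown here, the one readable step into it is an at least 1.9-fold higher number from compound 1 to compound 3 (0.29 log units; that floor lies within the scatter), and a step that the two limits leave unreadable from compound 2 to compound 3. Compound 4 `CC(C)[C@H](NC(=O)COc1cccc2ccccc12)C(=O)N[C@@H](CC(=O)O)C(=O)COc1cccc2cccnc12` differs by quinolin-8-yl in place of 4-(trifluoromethyl)pyrimidin-2-yl on an oxygen on a saturated carbon. For the measured compounds named here, no measured step exchanges one aryl ether for another with a readable size, so the direction from compound 3 cannot be taken from the data. Compound 4 is expected near the limit again, estimated at 150000 nM (range 40000 nM to 400000 nM), an expected step of an at least 1.3-fold lower number from compound 3 to compound 4 (0.12 log units; that floor lies within the scatter).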

Compound 4, half-maximal inhibitory concentration: > 200000 nM
Compound 4 gave a limit, no number; the forecaster's own chance of this, stated with the estimate: 50%; middle value at least 1.3-fold (0.12 log units) away from the limit.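

In this assay compound 4 returns only a limit, so an aryl ether without trifluoromethyl joins the two trifluoromethyl ethers there: the limit of > 200000 nM in this assay, at which 3 of the 4 values shown sit. Putting (quinolin-8-yl)oxy in place of (3-phenyl-1,2,4-oxadiazol-5-yl)sulfanyl reads as an at least 1.9-fold higher number from compound 1 to compound 4 (0.29 log units; that floor lies within the scatter). The steps to compound 4 from compound 2 and compound 3 cannot be read.

From the compounds shown here alone, the order among compound 2, compound 3 and compound 4 stays open. Also open, going by these compounds, is whether a (quinolin-8-yl)sulfanyl group, or an amine in place of the ether oxygen, would give a readable value in this assay.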